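The source may hold more compounds than are shown below. What is called first, only, known or untested is meant among the compounds shown, and "the series" means these compounds.

Compound 1, drawn as `O=C(c1cc(-c2ccc(Cl)cc2Cl)n[nH]1)N1CCOCC1`, and compound 2, drawn as `O=C(c1cc(-c2ccc(Cl)cc2Cl)n[nH]1)N(CCO)CCO`, share the same core and differ only in the group attached to the carbonyl carbon. In an assay on isolated protein for inhibition of alkaline phosphatase, tissue-nonspecific isozyme (Homo sapiens) (a lower number here means a stronger inhibitor, a higher number a weaker inhibitor), compound 1 gives 574 nM, while compound 2 gives 47 nM. That is a 12-fold lower number from compound 1 to compound 2 (1.09 log units; beyond the scatter). Within the data shown here, of the two numbers measured so far, compound 2 therefore holds the lower one, with compound 1 as its only neighbour.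

Compound 3, drawn as `NNC(=O)c1cc(-c2ccc(Cl)cc2Cl)n[nH]1`, is the next variation at the same position: aminoamino in place of bis(2-hydroxyethyl)amino on a carbonyl carbon. Among the measured compounds shown here, the one measured step that touches this position is the exchange at the carbonyl carbon from compound 1 to compound 2, which was large. It shows that this position can move the result strongly, but it does not tell in which direction a much smaller group with fewer acceptors will push it. With that single precedent, a change of moderate size is expected, most likely toward a somewhat higher number, giving a 3.2-fold higher number from compound 2 to compound 3 (0.50 log units; beyond the scatter). For compound 3 the estimate is 150 nM, with a range from 40 nM to 600 nM.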

Compound 3, half-maximal inhibitory concentration: 44 nM
Beside the measured number, compound 3's estimate is 3.4-fold (0.53 log units) above it; the range from low to high includes it.
By their numbers in this assay, from the lowest: compounds 3 and 2 (each within the scatter of the next); then compound 1.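

Aminoamino in place of bis(2-hydroxyethyl)amino on the carbonyl carbon gives a 1.1-fold lower number from compound 2 to compound 3 (0.03 log units; within the scatter) in this assay, so these two groups cannot be told apart here, although aminoamino has 2 heavy atoms and bis(2-hydroxyethyl)amino has 7. Aminoamino in place of morpholin-4-yl gives a 13-fold lower number from compound 1 to compound 3 (1.12 log units; beyond the scatter), a large step much like a 12-fold lower number from compound 1 to compound 2 (1.09 log units; beyond the scatter), so the low number does not depend on having the two hydroxyethyl chains. Morpholin-4-yl, the only one of the three groups with a ring, stands apart with the higher number, but three compounds show this only as an observation and not as a rule.

Nothing available explains why the two groups without a ring sit so far from morpholin-4-yl. Going by these compounds, it remains open whether a plain amino group, a single 2-hydroxyethylamino chain or a piperazine ring on the carbonyl carbon would fall with compound 1 or with compound 2 and compound 3.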